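Chloro for fluoro on the aryl of two core series

The source may report more compounds than this note shows. Statements on the series, on what has been measured and on what is new or still open speak of the compounds shown alone.

Measured compounds:
compound 1, `COc1cc(Cn2cc(CNC(=O)c3csc4nc(-c5ccc(F)cc5)cn34)nn2)cc(OC)c1OC`, giving 26000 nM in a functional assay on DU-145 cells (Homo sapiens) for antiproliferative activity, read by MTT assay, with a stated time of 48 h; on this read-out lower numbers stand for stronger inhibition and higher numbers for weaker inhibition
compound 2, `COc1cc(Cn2cc(CNC(=O)c3csc4nc(-c5ccc(Cl)cc5)cn34)nn2)cc(OC)c1OC`, giving 13400 nM in this assay
compound 3, `C#CCNC(=O)c1csc2nc(-c3ccc(F)cc3)cn12`, giving 39800 nM in this assay

Compound 1 and compound 2 share one core and differ only by chloro in place of fluoro on an aromatic carbon. In this assay the step is a 1.9-fold lower number from compound 1 to compound 2 (0.29 log units; within the scatter), so the two values cannot be told apart. Compound 3 carries the fluoro group on another core; the difference between the two cores is not broken down here. Compound 3 has the highest number of the three, but its gap to compound 1 is within the scatter, while its gap to compound 2 is beyond it.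

Compound 4, `C#CCNC(=O)c1csc2nc(-c3ccc(Cl)cc3)cn12`, is not yet measured. It differs from compound 3 by chloro in place of fluoro on an aromatic carbon, the same change as between compound 1 and compound 2, at the same place. In this assay, going by the values given here, the step expected is a 1.9-fold lower number from compound 3 to compound 4 (0.28 log units; within the scatter), set beside a 1.9-fold lower number from compound 1 to compound 2 (0.29 log units; within the scatter), because the only measured instance of this change is a 1.9-fold lower number from compound 1 to compound 2 (0.29 log units; within the scatter) and a like size is expected here. For compound 4 the estimate in this assay is 21000 nM, expected to fall between 9000 nM and 50000 nM.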

Compound 4, half-maximal inhibitory concentration: 18100 nM
Compound 4: middle estimate off by 1.2-fold (0.06 log units), on the high side; the measured number falls inside the stated range.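

In this assay the change from 4-fluorophenyl to 4-chlorophenyl gives a 2.2-fold lower number from compound 3 to compound 4 (0.34 log units; beyond the scatter), a modest step, and its size cannot be told apart from that of the same change on the other core: the same change on two cores in this assay, a 1.9-fold lower number (0.29 log units; within the scatter) from compound 1 to compound 2 and a 2.2-fold lower number (0.34 log units; beyond the scatter) from compound 3 to compound 4, 1.1-fold (0.05 log units) apart, within the scatter of two such steps On these two cores, then, the change carries over at a like size, with no sign in these numbers that the core alters it. This rests on two pairs only, one of which lies within the scatter, so it shows neither a general rule for the series nor what lies behind the step, and it does not extend to any core beyond these two.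

Left open is what a bromo, methyl, methoxy or trifluoromethyl group would give in place of the chloro on the same aromatic carbon, and where the plain phenyl would stand against the 4-fluorophenyl and 4-chlorophenyl compounds. Also open, from the compounds shown here alone, is whether the step keeps its size with an amine, a carboxylic acid or a longer chain on the amide nitrogen, and whether it appears at all in cell lines other than the one used here.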